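Methylamino analogue of the pyrazole bisamide series: permeability notes

The source may report more compounds than this note shows. Statements on the series, on what has been measured and on what is new or still open speak of the compounds shown alone.

Measured compounds:
compound 1 `CNC(=O)c1cc(C(=O)N[C@H]2CC[C@H](O)CC2)n([C@@H](C)c2ccccc2)n1` 80 nm/s
compound 2 `CNC(=O)c1cc(C(=O)N[C@H]2CC[C@H](OC)CC2)n([C@@H](C)c2ccccc2)n1` 360 nm/s

Among the measured compounds shown here, in an ADME assay for permeability (a lower number here means that the compound crosses the layer more slowly, a higher number that the compound crosses the layer faster), compound 2 gives 360 nm/s, the higher of the two numbers so far; its nearest neighbour is compound 1, which in this assay gives 80 nm/s. For the measured compounds named here, the only measured step, a 4.5-fold higher number from compound 1 to compound 2 (0.65 log units; beyond the scatter), concerns a different place in the molecule and does not share the change considered here.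

Compound 3 `CNC(=O)c1cc(C(=O)NC)n([C@@H](C)c2ccccc2)n1` differs from compound 2 by methyl in place of 4-methoxycyclohexyl on an amide-type nitrogen. Going by the values given here, no measured pair shows what this change does in this assay, so the expectation rests on the compounds at hand alone: the group that leaves is the one carrying the oxygen whose methylation gave the step from compound 1 to compound 2, and the group that enters is much smaller. Compound 3 is therefore estimated at 220 nm/s, within 80 nm/s to 550 nm/s, which means an expected step of a 1.6-fold lower number from compound 2 to compound 3 (0.21 log units; within the scatter), not clearly beyond the scatter in either direction.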

Compound 3, apparent permeability: 280 nm/s
The estimate for compound 3 lay 1.3-fold (0.10 log units) below the measured number; low and high end bracket the measured number.
By their numbers in this assay, from the lowest: compound 1; then compounds 3 and 2 (each within the scatter of the next).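

At this amide-type nitrogen, 4-methoxycyclohexyl gives way to methyl with a 1.3-fold lower number from compound 2 to compound 3 (0.11 log units; within the scatter), so in this assay the six-membered ring and its methoxy group can be lost without a step beyond the scatter. Measured against the hydroxy compound, the same position gives a 3.5-fold higher number from compound 1 to compound 3 (0.54 log units; beyond the scatter), which now sets a second step beyond the scatter beside a 4.5-fold higher number from compound 1 to compound 2 (0.65 log units; beyond the scatter): among these three compounds, 4-hydroxycyclohexyl in compound 1 stands apart, while methyl in compound 3 and 4-methoxycyclohexyl in compound 2 cannot be told apart. No evidence on why these numbers fall as they do is available, and the three compounds describe the pattern without explaining it.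

On these data alone, whether a plain cyclohexyl, a longer chain such as n-butyl, or a 4-aminocyclohexyl on this nitrogen would fall with compound 1 or with compounds 2 and 3 remains open. Also open, as far as these compounds go, is whether the same pattern holds when the methylamide or the 1-phenylethyl group of the shared core is replaced, for example by a carboxylic acid or a benzyl group.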